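Working notes: ethoxy for iodo in the hydrazone series

A few compounds are considered here, and "the series" means these few. Any claim that something is new, unique, unknown or untested is made for them only; others in the source may bear on it.

Going by the values given here, compound 2 `CC1CC/C(=N\Nc2cccc(I)c2)c2ncc(C(=O)O)c(=O)n21` is the one measured compound with a number: in a functional assay on the whole organism for inhibition, with Rattus norvegicus as the target (a lower number here means that less compound is needed, a higher number that more compound is needed for the effect), compound 2 gives 1000 umol/kg. Among the compounds with values here, the only other value in the set is a limit rather than a number. Compound 1 `CC1CC/C(=N\Nc2cccc(Cl)c2)c2ncc(C(=O)O)c(=O)n21` carries chloro where compound 2 carries iodo. In this assay compound 1 gives only the limit > 100 umol/kg. The step that the limit leaves unreadable from compound 1 to compound 2 therefore cannot be sized, as the limit of > 100 umol/kg in this assay, at which 1 of the 2 values shown sits, leaves that comparison at a limit.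

Compound 3 `CCOc1cccc(N/N=C2\CCC(C)n3c2ncc(C(=O)O)c3=O)c1` differs from compound 2 by ethoxy in place of iodo on an aromatic carbon. Within the data shown here, no measured step in the set involves an ethoxy group, and the one measured step at that aromatic carbon is unreadable. The expectation therefore rests on compound 2 alone, and the step of no change at the digits printed from compound 2 to compound 3 (within the scatter) is expected to stay within the scatter. Compound 3 is thus estimated to give 1000 umol/kg in this assay, with a range from 300 umol/kg to 3000 umol/kg.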

Compound 3, dose for 50% inhibition: > 1000 umol/kg
Compound 3 gave a limit, no number; the forecaster's own chance of this, stated with the estimate: 30%; the middle value sits exactly at the limit.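

Ethoxy in place of iodo on an aromatic carbon gives a number no lower from compound 2 to compound 3 (the limit leaves the size open), so in this assay ethoxy at this place, with its 3 heavy atoms and 1 hydrogen-bond acceptor, does not bring the number under that of iodo. For compound 3 the reading ends at a limit: the limit of > 1000 umol/kg in this assay, at which 1 of the 3 values shown sits.

The size of that step cannot be read, nor can the step between compound 1 and compound 3, so chloro, iodo and ethoxy at this place cannot be put in order.

The compounds shown leave open whether any group on this aromatic carbon gives a clearly lower number, for instance an amine or a carboxylic acid. They also leave open whether a longer chain joined through oxygen would behave as ethoxy does.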